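Working notes: cytotoxicity limits across two ether cores

The source may hold more compounds than are shown below. What is called first, only, known or untested is meant among the compounds shown, and "the series" means these compounds.

Measured compounds, with values in an ADME assay on Vero cells (Chlorocebus sabaeus) for cytotoxicity, with a stated time of 72 h; a higher number here means a weaker inhibitor, a lower number a stronger inhibitor:
- compound 1 `O=[N+]([O-])c1cn2c(n1)OC[C@@H](OCc1cnn(-c3ccc(F)cc3)c1)C2`: > 128000 nM
- compound 2 `O=[N+]([O-])c1cn2c(n1)OC[C@@H](OCc1cnn(-c3ccc(OC(F)(F)F)cc3)c1)C2`: > 128000 nM
- compound 3 `O=[N+]([O-])c1cn2c(n1)OC[C@@H](OCc1cc(-c3ccc(F)cc3)no1)C2`: > 128000 nM

Each of these three values is a limit of this assay, not a number; the limit of > 128000 nM in this assay, at which 3 of the 3 values shown sit, applies to all of them. Compound 1 and compound 2 differ by trifluoromethoxy in place of fluoro on an aromatic carbon, and this gives a step that the two limits leave unreadable from compound 1 to compound 2. Compound 3 carries a different core; the difference between the two cores is not broken down here.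

Compound 4 `O=[N+]([O-])c1cn2c(n1)OC[C@@H](OCc1cc(-c3ccc(OC(F)(F)F)cc3)no1)C2` is not yet measured. It differs from compound 3 by trifluoromethoxy in place of fluoro on an aromatic carbon, the same change as from compound 1 to compound 2. With compound 1 giving > 128000 nM and compound 2 giving > 128000 nM, the step is expected to be small, a step that the limit leaves unreadable from compound 3 to compound 4. For compound 4 the estimate in this assay is 150000 nM, between 64000 nM and 500000 nM, most likely reported again as a limit.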

Compound 4, half-maximal inhibitory concentration: > 128000 nM
Compound 4: no number, only a limit (the forecaster's own chance of this, stated with the estimate: 85%); the middle value lies beyond the limit too.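

Within the data shown here, compound 3 and compound 4 both sit at a limit, not a number, in this assay, so no step between them can be read: the limit of > 128000 nM in this assay, at which 4 of the 4 values shown sit.

The compounds shown leave open whether trifluoromethoxy in place of fluoro, or the difference between the two cores, changes cytotoxicity at all.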